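A few compounds are considered here, and "the series" means these few. Any claim that something is new, unique, unknown or untested is made for them only; others in the source may bear on it.

Compounds measured in a functional assay on LNCaP cells (Homo sapiens) for cytotoxicity, read by MTT assay, with a stated time of 72 h; a lower number here means a stronger inhibitor, a higher number a weaker inhibitor:
compound 1 `COc1cc(OC)cc(/C(=C\c2cn(C(C)=O)c3ccc(OCc4ccccc4)cc23)C(=O)O)c1` — 26100 nM
compound 2 `COc1cc(/C(=C\c2cn(C(C)=O)c3ccc(OCc4ccccc4)cc23)C(=O)O)cc(OC)c1OC` — 59600 nM
compound 3 `COc1ccc(/C(=C\c2c[nH]c3ccc(OCc4ccccc4)cc23)C(=O)O)cc1` — "not determined" (no result reported), no number reported

Compound 1 holds the lowest of the two numbers in this assay; its nearest neighbour is compound 2, and the step of a 2.3-fold higher number from compound 1 to compound 2 (0.36 log units; beyond the scatter) is modest though beyond the scatter. Compound 4 `COc1ccccc1/C(=C\c1cn(C(C)=O)c2ccc(OCc3ccccc3)cc12)C(=O)O` has not yet been tested. It differs from compound 1 in one place: 2-methoxyphenyl in place of 3,5-dimethoxyphenyl on a double-bonded chain carbon bound to a carbonyl carbon and a double-bonded chain carbon. Within the data shown here, the only measured step, from compound 1 to compound 2, adds a methoxy rather than moving one, so it bears on the new change only loosely; it shows that a small shift in methoxy count costs little. Compound 4 is therefore expected to stay near compound 1, with a step of a 1.1-fold higher number from compound 1 to compound 4 (0.06 log units; within the scatter) that need not exceed the scatter. The estimate for compound 4 in this assay is 30000 nM, expected between 10000 nM and 90000 nM.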

Compound 4, half-maximal inhibitory concentration: 48500 nM
The estimate for compound 4 lay 1.6-fold (0.21 log units) below the measured number; measured number inside the range.
By their numbers in this assay, from the lowest: compounds 1, 4 and 2 (each within the scatter of the next, the first and the last beyond it).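

Within this assay, a single methoxy group on the phenyl ring at this place reads much like two or three: 2-methoxyphenyl in place of 3,5-dimethoxyphenyl stays within the scatter (a 1.9-fold higher number from compound 1 to compound 4 (0.27 log units; within the scatter)), as does 2-methoxyphenyl in place of 3,4,5-trimethoxyphenyl (a 1.2-fold lower number from compound 2 to compound 4 (0.09 log units; within the scatter)). Compound 4 thus cannot be separated from either compound 1 or compound 2, although those two lie beyond the scatter of each other. Nothing available gives a cause for this.

Compound 4 alters the number and the place of the methoxy groups together, so the two changes remain unseparated. On these data alone, how a phenyl ring bearing an amine at this place would read remains open.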